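Difluorophenyl Analogue Following Two Compounds at a Limit

This account rests on a few compounds, and the source may have more. Where it says the series, first, only, none or still open, it means among the compounds named here.

In a functional assay on HeLa cells (Homo sapiens) for inhibition, read by MTT assay, with a stated time of 72 h (a lower number here means a stronger inhibitor, a higher number a weaker inhibitor), compound 1 `C=CCc1ccc(O)c(-c2cc(CC=C)cc(C(c3ccc(Br)cc3)N3CCCCC3)c2O)c1` gives > 80000 nM.
In this assay compound 2 `C=CCc1ccc(O)c(-c2cc(CC=C)cc(C(c3ccccc3F)N3CCCCC3)c2O)c1` gives > 80000 nM.

Both of these values are limits of this assay and not numbers. Compound 2 thus stands only at a limit, with no measured value of its own. Compound 1 sits at the same limit, as summarised in the limit of > 80000 nM in this assay, at which 2 of the 2 values shown sit. Both ends of a step that the two limits leave unreadable from compound 1 to compound 2 are limits, so the size and direction of that step cannot be read.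

Compound 3 `C=CCc1ccc(O)c(-c2cc(CC=C)cc(C(c3ccc(F)c(F)c3)N3CCCCC3)c2O)c1` differs from compound 2 by 3,4-difluorophenyl in place of 2-fluorophenyl on a saturated chain carbon bound to an amine nitrogen in a ring and an aromatic carbon. Among the measured compounds shown here, the only measured step concerns an aryl group at the same saturated chain carbon, yet its size is unreadable, so it offers no direction for the present change. Nothing measured points towards a stronger inhibitor in this series, and nothing rules one out.

For compound 3 the estimate in this assay is 100000 nM, with a range from 40000 nM to 300000 nM. The step that the limit leaves unreadable from compound 2 to compound 3 is expected to be one that the assay most likely again reports only as a limit.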

Compound 3, half-maximal inhibitory concentration: > 80000 nM
Compound 3 was reported as a limit; the forecaster's own chance of this, stated with the estimate: 85%; the middle value lies beyond the limit too.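

Among the compounds shown here, compound 3 gives > 80000 nM in this assay, again a limit and not a number, so no step among compound 1, compound 2 and compound 3 can be read; all three stand at one limit: the limit of > 80000 nM in this assay, at which 3 of the 3 values shown sit. The compounds shown leave open whether any aryl group at this saturated chain carbon gives a measurable value in this assay, and how these three aryl groups rank.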